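Nitro in Place of Ethoxycarbonyl: What to Expect

The source may report more compounds than this note shows. Statements on the series, on what has been measured and on what is new or still open speak of the compounds shown alone.

Of the compounds shown here, three with a shared core have been measured in a functional assay on A-375 cells (Homo sapiens) for inhibition; a higher number here means a weaker inhibitor, a lower number a stronger inhibitor. Compound 1 `CCOC(=O)c1ccc(NC(=O)N2CC2C#N)cc1` gives 5800 nM in this assay. Compound 2 `N#CC1CN1C(=O)Nc1ccc(Cl)c(Cl)c1` gives 5900 nM, and compound 3 `CC(=O)c1cccc(NC(=O)N2CC2C#N)c1` gives 7900 nM. Compound 1 has the lowest of the three numbers, but its gap to compound 2 and its gap to compound 3 both lie within the usual scatter, so the three cannot be ranked against each other.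

Compound 4 `N#CC1CN1C(=O)Nc1ccc([N+](=O)[O-])cc1` has not yet been measured. It differs from compound 1 in one place: nitro in place of ethoxycarbonyl on an aromatic carbon. Going by the values given here, no step between two measured compounds matches this change, so the expectation rests on the narrow spread seen so far. The expected step is a 1.1-fold lower number from compound 1 to compound 4 (0.02 log units; within the scatter), small and without a direction beyond the scatter. Compound 4 is therefore estimated at about 5500 nM, within a range from 2500 nM to 12000 nM.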

Compound 4, half-maximal inhibitory concentration: 3900 nM
Beside the measured number, compound 4's estimate is 1.4-fold (0.15 log units) above it; the range from low to high includes it.
By their numbers in this assay, from the lowest: compounds 4, 1, 2 and 3 (each within the scatter of the next, the first and the last beyond it).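

Putting nitro in place of ethoxycarbonyl on this aromatic carbon gives a 1.5-fold lower number from compound 1 to compound 4 (0.17 log units; within the scatter) in this assay, so this single change moves the number by no more than the scatter. The swap replaces a group of 5 heavy atoms with one of 3, and both groups have 2 hydrogen-bond acceptors and no hydrogen-bond donors. No measurement shown bears on what lies behind this result. As far as these compounds go, it remains open whether an amine or a carboxylic acid on the same carbon would also stay within the scatter of compound 1. From the compounds shown here alone, a longer ester chain in place of ethoxycarbonyl is equally open.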